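Aryl replacement on the ethenyl arm: outlook for compound 3

This account rests on a few compounds, and the source may have more. Where it says the series, first, only, none or still open, it means among the compounds named here.

Measured so far in an assay on cells for inhibition of Ectonucleotide pyrophosphatase/phosphodiesterase family member 1 (Homo sapiens), with a stated time of 60 min; a higher number here means a weaker inhibitor, a lower number a stronger inhibitor:
compound 1 `COc1cc2nc(/C=C/c3ccncc3)nc(N3CCC(CCNS(N)(=O)=O)CC3)c2cc1OC` gives 218 nM
compound 2 `COc1cc2nc(/C=C/c3cccc(F)c3)nc(N3CCC(CCNS(N)(=O)=O)CC3)c2cc1OC` gives 3580 nM

Compound 1 holds the lower of the two numbers. For the measured compounds named here, the single step known, a 16-fold higher number from compound 1 to compound 2 (1.22 log units; beyond the scatter), shows that a carbon-only ring in place of pyridin-4-yl on the ethenyl arm costs a great deal in this assay. Compound 3 `COc1ccccc1/C=C/c1nc(N2CCC(CCNS(N)(=O)=O)CC2)c2cc(OC)c(OC)cc2n1` carries the change (2-methoxyphenyl in place of pyridin-4-yl on a double-bonded chain carbon bound to a double-bonded chain carbon), again a carbon-only ring, now with a methoxy group. Going by the values given here, with that step as the only guide, a loss of similar size is expected, an 11-fold higher number from compound 1 to compound 3 (1.06 log units; beyond the scatter). Compound 3 is therefore estimated at 2500 nM, range 700 nM to 9000 nM.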

Compound 3, inhibition constant: 302 nM
Compound 3: middle estimate off by 8.3-fold (0.92 log units), on the high side; measured number below the stated range.
By their numbers in this assay, from the lowest: compounds 1 and 3 (each within the scatter of the next); then compound 2.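

In this assay, the ring nitrogen of pyridin-4-yl proves dispensable on the ethenyl arm, with 2-methoxyphenyl giving a 1.4-fold higher number from compound 1 to compound 3 (0.14 log units; within the scatter) despite its carbon-only ring. Carbon-only rings also differ widely among themselves, with a 12-fold lower number from compound 2 to compound 3 (1.07 log units; beyond the scatter), so the loss seen with 3-fluorophenyl does not extend to both such rings shown. No measurement here accounts for this difference.

Still open, going by these compounds, is what unsubstituted phenyl, 2-fluorophenyl or 3-methoxyphenyl gives on this arm, which would separate the choice of substituent from its place on the ring.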